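Shortening the hydroxyalkyl chain of compound 1

The source may hold more compounds than are shown below. What is called first, only, known or untested is meant among the compounds shown, and "the series" means these compounds.

Compound 1 `OCCCNc1nc(-c2ccccc2)nc2c1nnn2Cc1ccccc1Cl` gives 33000000 nM in an assay on isolated protein for binding affinity to adenosine receptor A1 (Bos taurus); on this read-out lower numbers stand for stronger inhibition and higher numbers for weaker inhibition.
Compound 2 `OCCCNc1nc(-c2ccccc2)nc2c1nnn2Cc1ccccc1` gives 21400000 nM in this assay.
Compound 3 `FC(F)(F)c1ccccc1Cn1nnc2c(NC3CCCC3)nc(-c3ccccc3)nc21` gives 600000 nM in this assay.

Among the three numbers measured in this assay, compound 1 holds the highest. Its nearest neighbour is compound 2, reached by a 1.5-fold lower number from compound 1 to compound 2 (0.19 log units; within the scatter), a step that stays within the scatter. Among the compounds with values here, compound 3 gives a number far below that of compound 1, but the two structures differ in more than one place, so no single step between them can be read from these values.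

Compound 4 `OCCNc1nc(-c2ccccc2)nc2c1nnn2Cc1ccccc1Cl` differs from compound 1 by hydroxy in place of hydroxymethyl on a saturated chain carbon, two bonds along the chain from a nitrogen on an aromatic ring. Within the data shown here, none of the measured steps touches this chain: the only single-place step, a 1.5-fold lower number from compound 1 to compound 2 (0.19 log units; within the scatter), concerns a chloro on an aromatic carbon, and compound 3 differs from compound 1 at several places at once. With nothing bearing directly on the change, the expectation for this assay is no step beyond the scatter. Compound 4 is therefore estimated at 30000000 nM, with a range from 8000000 nM to 110000000 nM. Expressed as a step, this estimate means a 1.1-fold lower number from compound 1 to compound 4 (0.04 log units; within the scatter).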

Compound 4, inhibition constant: 116000000 nM
The estimate for compound 4 lay 3.9-fold (0.59 log units) below the measured number; the whole stated range lies below it.
By their numbers in this assay, from the lowest: compound 3; then compounds 2 and 1 (each within the scatter of the next); then compound 4.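

In this assay, within the data shown here, this is the first measured step that touches the chain on the aromatic-ring nitrogen: replacing (3-hydroxypropyl)amino with (2-hydroxyethyl)amino gives a 3.5-fold higher number from compound 1 to compound 4 (0.55 log units; beyond the scatter). The step is modest, but unlike the exchange of chloro for hydrogen, which gave a 1.5-fold lower number from compound 1 to compound 2 (0.19 log units; within the scatter), it lies beyond the scatter, so this chain position registers a change that removes a single carbon while the hydroxy stays in place, and the higher number means weaker inhibition. Nothing available explains why the shorter chain gives the higher number.

The compounds shown leave open whether a longer chain would continue this trend or reverse it, and whether an amine or a carboxylic acid in place of the hydroxy would matter more than the chain length does. On these data alone, it also remains open whether the same shortening would give a step of similar size on the core of compound 2, which carries hydrogen in place of chloro, since this single pair cannot show whether the effect depends on that substituent.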